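The source may report more compounds than this note shows. Statements on the series, on what has been measured and on what is new or still open speak of the compounds shown alone.

In a physicochemical assay for lipophilicity, in phosphate buffer, measured as octanol-water partition, at pH 11.5 (a higher number here means a more lipophilic compound, a lower number a more polar compound), compound 3 (`CCOC(=N)NC(=N)Nc1ccc(Cl)cc1`) gives 2.32, the lowest of the three numbers. Compound 2 (`CCCNC(=N)NC(=N)Nc1ccc(Cl)cc1`) stands higher at 2.63, and compound 1 (`CCCCC(CC)CNC(=N)NC(=N)Nc1ccc(Cl)cc1`) stands highest at 4.93.

The next structure, compound 4 (`CCNC(=N)NC(=N)Nc1ccc(Cl)cc1`), has ethylamino in place of ethoxy on a carbon with a double bond to nitrogen.

Within the data shown here, two measured steps bear on this change, and they point in opposite directions. The modest a number 0.31 log units lower from compound 2 to compound 3 (beyond the scatter) put ethoxy where propylamino had been, so going back to an amino group at that place suggests a small rise. The large a number 2.30 log units lower from compound 1 to compound 2 (beyond the scatter) came with a shorter chain on the amine nitrogen, and the ethylamino of compound 4 is shorter than the propylamino of compound 2, which suggests a fall. Taken together, these steps lead to the expectation of little net movement in this assay, perhaps slightly downward.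

The expected change is a number 0.12 log units lower from compound 3 to compound 4 (within the scatter), with no shift beyond the scatter anticipated. For compound 4 the estimated value is 2.2, with an expected range from 1.9 to 2.5.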

Compound 4, partition coefficient: 2.14
For compound 4 the middle estimate is 0.06 log units above the measured one, within the range that was stated.
By their numbers in this assay, from the lowest: compounds 4 and 3 (each within the scatter of the next); then compound 2; then compound 1.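

In this assay, ethylamino in place of ethoxy on a carbon with a double bond to nitrogen gives a number 0.18 log units lower from compound 3 to compound 4 (within the scatter), so this read-out does not separate the two groups, although ethylamino carries a hydrogen-bond donor that ethoxy lacks. With compound 4, the chain on the amine nitrogen forms a short series: hydrogen in place of methyl gives a number 0.49 log units lower from compound 2 to compound 4 (beyond the scatter), and methyl in place of 1-ethylpentyl gives a number 2.79 log units lower from compound 1 to compound 4 (beyond the scatter), so the number falls with each shortening across these three compounds. Nothing shown here accounts for these steps.

Going by these compounds, whether a methoxy group or an unsubstituted amine at this place would also stay within the scatter of compound 3 remains open. So does whether ethoxy and ethylamino would still match when paired with a longer chain, such as a butoxy group against a butylamino group.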